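The source may report more compounds than this note shows. Statements on the series, on what has been measured and on what is new or still open speak of the compounds shown alone.

Working notes on the series. In a functional assay on HL-60 cells (Homo sapiens) for inhibition (a higher number here means a weaker inhibitor, a lower number a stronger inhibitor), compound 1 (`CC(C)CN(C)Cc1ccc(C2=CCCN(C)C2)cc1`) has no number to start from, and its entry reads "not determined" (no result reported). Compound 2 (`COc1ccc(CN(C)Cc2ccc(C3=CCCN(C)C3)cc2)cc1`) is in the same position, with "not determined" (no result reported). The only numerical result so far belongs to compound 3 (`CN1CCC=C(c2ccc(CN(C)Cc3ccc(Cl)cc3)cc2)C1`), which gives 2140 nM. Compound 4 (`CN1CCC=C(c2ccc(CN(C)C/C=C/c3ccccc3)cc2)C1`) has not yet been measured.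

The structural change under consideration is 2-phenylethenyl in place of isopropyl on a saturated chain carbon bound to an amine nitrogen. Going by the values given here, with no value for compound 1, no step from it can be sized in this assay, and no measured pair shows what such a change does. Compound 3 also carries a six-membered aromatic ring of carbon only on its amine side chain, so its 2140 nM serves as the sole reference. A result for compound 4 is expected to fall within the usual scatter of that level, with no direction favoured. For compound 4 the estimated value is 2000 nM, with an expected range of 700 nM to 6000 nM.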

Compound 4, half-maximal inhibitory concentration: 680 nM
Compound 4: middle estimate off by 2.9-fold (0.47 log units), on the high side; measured number outside the range, below it.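

In this assay, the position on a saturated chain carbon bound to an amine nitrogen now has its first measured comparison: 2-phenylethenyl in place of 4-chlorophenyl gives a 3.1-fold lower number from compound 3 to compound 4 (0.50 log units; beyond the scatter). Both compounds carry a six-membered aromatic ring of carbon only in this group, so the presence of that ring alone does not fix the level of the read-out. No measured data are available to explain the shift.

The step from compound 1 to compound 4, isopropyl to 2-phenylethenyl, cannot be read, as compound 1 has no number. The compounds shown leave open how a 2-phenylethyl group would compare at this position, and with it whether the double bond outside aromatic rings matters to the result.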